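The compounds below may be only part of what the source reports. "The series", "measured", "known", "first", "only" and "open" are said of these compounds alone.

Measured so far in an assay on HEK293 cells for displacement of a labelled ligand from adenosine receptor A1 (Homo sapiens), read by scintillation counting, with a stated time of 60 min; a lower number here means a stronger inhibitor, a higher number a weaker inhibitor:

Compound 1, `CCn1c(/N=C/c2ccc(F)cc2)c(C#N)sc1=S`: 0.00059 nM
Compound 2, `CCn1c(/N=C/c2ccc(Cl)cc2)c(C#N)sc1=S`: 19.8 nM

Among the compounds with values here, compound 2 stands at the higher of the two numbers; its only neighbour is compound 1, and the step of a 34000-fold higher number from compound 1 to compound 2 (4.53 log units; beyond the scatter) separates them, the single change being chloro in place of fluoro on an aromatic carbon.

Compound 3, `CCn1c(/N=C/c2ccc(Br)cc2)c(C#N)sc1=S`, is not yet measured. Its change from compound 2 is bromo in place of chloro on an aromatic carbon.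

Within the data shown here, the one measured step that bears on this change is a 34000-fold higher number from compound 1 to compound 2 (4.53 log units; beyond the scatter), an exchange of one group for another on an aromatic carbon, and it was large. Among the measured compounds shown here, a single step of that kind cannot tell whether the numbers keep moving the same way with bromo or turn back; it shows only that a small change at this place can move the number very far. The expected step of a 2.0-fold higher number from compound 2 to compound 3 (0.31 log units; beyond the scatter) is therefore kept modest, toward a higher number, with a wide range around it. Compound 3 is expected to give about 40 nM in this assay, between 5 nM and 300 nM.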

Compound 3, inhibition constant: 0.00074 nM
For compound 3 the middle estimate is 54000-fold (4.73 log units) above the measured one, and the stated range ends above it.
By their numbers in this assay, from the lowest: compounds 1 and 3 (each within the scatter of the next); then compound 2.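

In this assay the step of a 27000-fold lower number from compound 2 to compound 3 (4.43 log units; beyond the scatter) runs opposite to the earlier step of a 34000-fold higher number from compound 1 to compound 2 (4.53 log units; beyond the scatter) and is of similar size, so the numbers at this place on the aromatic ring do not move in one direction from fluoro through chloro to bromo, and compound 2 goes against any such trend. The step of a 1.3-fold higher number from compound 1 to compound 3 (0.10 log units; within the scatter) lies within the scatter, which means that fluoro and bromo cannot be told apart here, while the chloro of compound 2 alone stands far from both. Nothing given here accounts for this separation of the chloro compound from the other two.

From the compounds shown here alone, with only these three halogen compounds, it remains open whether the value of compound 2 is an isolated case at this place or one of several such departures. Going by these compounds, it is also open whether iodo, methoxy, an amine or a carboxylic acid at the same place would fall with compounds 1 and 3 or with compound 2, and whether a longer chain in place of the ethyl group on the shared core would leave this pattern intact.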